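The source may hold more compounds than are shown below. What is called first, only, known or untested is meant among the compounds shown, and "the series" means these compounds.

Measured compounds:
Compound 1 `O=C(CSC(=S)N[C@H]1CCOC1=O)Nc1ccccc1F` — in a functional assay on SMMC-7721 cells (Homo sapiens) for cytotoxicity, read by MTT assay, with a stated time of 72 h (a lower number here means a stronger inhibitor, a higher number a weaker inhibitor), compound 1 gives only a limit, > 128000 nM.
Compound 2 `O=C(CSC(=S)N[C@H]1CCOC1=O)Nc1cccc(Cl)c1` — in this assay compound 2 gives only a limit, > 128000 nM.
Compound 3 `O=C(CSC(=S)N[C@H]1CCOC1=O)Nc1ccccc1Cl` — in this assay compound 3 gives 49900 nM.

Compound 2 therefore stands at the limit of this assay, together with compound 1 (the limit of > 128000 nM in this assay, at which 2 of the 3 values shown sit); only compound 3 yields a number. The step from compound 1 to compound 2 is a step that the two limits leave unreadable from compound 1 to compound 2. The step from compound 2 to compound 3 is an at least 2.5-fold lower number from compound 2 to compound 3 (0.40 log units; beyond the scatter), and the step from compound 1 to compound 3 is an at least 2.5-fold lower number from compound 1 to compound 3 (0.40 log units; beyond the scatter).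

Compound 4 `O=C(CSC(=S)N[C@H]1CCOC1=O)Nc1cccc(C(F)(F)F)c1` differs from compound 2 by trifluoromethyl in place of chloro on an aromatic carbon. Among the compounds with values here, no measured step exchanges chloro for trifluoromethyl. Within the data shown here, the only step that swaps one ring substituent for another at an unchanged place, from compound 1 to compound 3, is an at least 2.5-fold lower number from compound 1 to compound 3 (0.40 log units; beyond the scatter), but it concerns a different pair of groups and the 2-substituted phenyl, so it is a weak guide. The 3-chlorophenyl compound 2 itself sits at the limit, and nothing measured shows that a larger group at the same place reaches a number.

Compound 4 is therefore expected to remain near the limit, estimated at 120000 nM in this assay, within 40000 nM to 300000 nM. The expected step from compound 2 to compound 4 is an at least 1.0-fold lower number from compound 2 to compound 4 (0.02 log units; that floor lies within the scatter), not readable as a change beyond the scatter.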

Compound 4, half-maximal inhibitory concentration: > 128000 nM
Compound 4 ended at the assay's limit (the forecaster's own chance of this, stated with the estimate: 60%); at least 1.0-fold (0.02 log units) between middle value and limit.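

Compound 2 and compound 4 both sit at the limit of this assay and give no number, so no step can be read between them. As far as these compounds go, it remains open whether chloro and trifluoromethyl differ at all at this place, and whether any other group there would yield a number, as the 2-chlorophenyl of compound 3 does.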